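Methyl Homologation in Two Places on a Shared Core

The source may report more compounds than this note shows. Statements on the series, on what has been measured and on what is new or still open speak of the compounds shown alone.

Measured so far in a functional assay for inhibition, with Homo sapiens as the target; on this read-out higher numbers stand for weaker inhibition and lower numbers for stronger inhibition:
compound 1, `COC(=O)C(Cc1cccc(OCC(=O)O)c1)c1nc(-c2ccccc2)c(-c2ccccc2)o1`: 80 nM
compound 2, `CCOC(=O)C(Cc1cccc(OCC(=O)O)c1)c1nc(-c2ccccc2)c(-c2ccccc2)o1`: 120 nM
compound 3, `CC(C)C(Cc1cccc(OCC(=O)O)c1)c1nc(-c2ccccc2)c(-c2ccccc2)o1`: 970 nM

Compound 2 differs from compound 1 by methyl in place of hydrogen on a saturated chain carbon bound to an oxygen next to a carbonyl group, and this gave a 1.5-fold higher number from compound 1 to compound 2 (0.18 log units; within the scatter). Compound 3 differs from compound 1 by isopropyl in place of methoxycarbonyl on a saturated chain carbon bound to an aromatic carbon and a saturated chain carbon, a change that gave a 12-fold higher number from compound 1 to compound 3 (1.08 log units; beyond the scatter), while against compound 2 the gap is an 8.1-fold higher number from compound 2 to compound 3 (0.91 log units; beyond the scatter). Compound 4, `CC(C)(C)C(Cc1cccc(OCC(=O)O)c1)c1nc(-c2ccccc2)c(-c2ccccc2)o1`, has not yet been measured in this assay; it differs from compound 3 by methyl in place of hydrogen on a saturated chain carbon bound to three saturated chain carbons. This is the same kind of change as that from compound 1 to compound 2, but not the same: there the carbon is bound to an oxygen next to a carbonyl group, here it is bound to three saturated chain carbons, and the cores differ as described. Compound 4 is expected to show a 1.3-fold higher number from compound 3 to compound 4 (0.13 log units; within the scatter), an expectation that rests on compound 2 and its step of a 1.5-fold higher number from compound 1 to compound 2 (0.18 log units; within the scatter), set against the uncertainty of a different core. Compound 4 is estimated at 1300 nM, with a likely range from 500 nM to 3500 nM.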

Compound 4, half-maximal inhibitory concentration: 3660 nM
Beside the measured number, compound 4's estimate is 2.8-fold (0.45 log units) below it, and the stated range ends below it.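

In this assay, methyl in place of hydrogen on the isopropyl group gave a 3.8-fold higher number from compound 3 to compound 4 (0.58 log units; beyond the scatter), while tert-butyl in place of ethoxycarbonyl gave a 31-fold higher number from compound 2 to compound 4 (1.48 log units; beyond the scatter) and tert-butyl in place of methoxycarbonyl gave a 46-fold higher number from compound 1 to compound 4 (1.66 log units; beyond the scatter). Set beside the earlier methyl step, the change shows no difference that can be told apart when carried from one core to the other: the same change on two cores in this assay, a 1.5-fold higher number (0.18 log units; within the scatter) from compound 1 to compound 2 and a 3.8-fold higher number (0.58 log units; beyond the scatter) from compound 3 to compound 4, 2.5-fold (0.40 log units) apart, within the scatter of two such steps. Among these compounds, this rests on only two pairs, so it does not show that the step keeps one size on other cores.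

The compounds shown leave open how an amide or an amine in place of methoxycarbonyl would read. They also leave open what a longer chain in place of tert-butyl would give.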